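The compounds below may be only part of what the source reports. "The series", "measured", "known", "first", "only" and "open" are said of these compounds alone.

Working notes on the series in a functional assay on PC-3 cells (Homo sapiens) for cytotoxicity, read by MTT assay, with a stated time of 72 h; a higher number here means a weaker inhibitor, a lower number a stronger inhibitor.

Compound 1 `CCOc1ccccc1Nc1nc(SCc2ccc(C(F)(F)F)cc2)nc2ccccc12` is the weaker of the two measured analogues: in this assay compound 1 gives 26200 nM. Compound 2 `FC(F)(F)c1ccc(CSc2nc(Nc3cccc(C(F)(F)F)c3)c3ccccc3n2)cc1` carries a 3-(trifluoromethyl)phenyl on the ring nitrogen in place of the 2-ethoxyphenyl, and in this assay compound 2 gives 12900 nM. That single exchange gives a 2.0-fold lower number from compound 1 to compound 2 (0.31 log units; beyond the scatter), a modest gain. Within the data shown here, compound 2 therefore holds the lowest number of the two, with compound 1 as its only neighbour.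

Compound 3 `FC(F)(F)c1ccc(CSc2nc(Nc3cccc(Cl)c3)c3ccccc3n2)cc1` is not yet measured. It differs from compound 2 by chloro in place of trifluoromethyl on an aromatic carbon. Among the measured compounds shown here, no measured step touches this position on its own; the one step recorded, from compound 1 to compound 2, swaps the whole aryl group, so it gives no direct precedent. With nothing to point either way, the change is expected to leave this assay roughly where compound 2 sits, within or near the scatter, as a 1.2-fold higher number from compound 2 to compound 3 (0.07 log units; within the scatter). Compound 3 is therefore estimated at 15000 nM, with a range from 7000 nM to 35000 nM.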

Compound 3, half-maximal inhibitory concentration: 13400 nM
The estimate for compound 3 lay 1.1-fold (0.05 log units) above the measured number; measured number inside the range.
By their numbers in this assay, from the lowest: compounds 2, 3 and 1 (each within the scatter of the next, the first and the last beyond it).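

In this assay, chloro in place of trifluoromethyl on this aromatic carbon gives a 1.0-fold higher number from compound 2 to compound 3 (0.02 log units; within the scatter), so replacing the four heavy atoms of trifluoromethyl with the single chlorine atom produces no readable change at this site. The exchange of the whole aryl group gives a 2.0-fold lower number from compound 1 to compound 3 (0.29 log units; within the scatter) with 3-chlorophenyl in place of 2-ethoxyphenyl, which stands within the scatter, whereas a 2.0-fold lower number from compound 1 to compound 2 (0.31 log units; beyond the scatter) with 3-(trifluoromethyl)phenyl lies just beyond it, so the two aryl exchanges differ only in how they fall against the scatter. No measured evidence bears on these results.

As far as these compounds go, whether a methoxy, an amine or a carboxylic acid on this same aromatic carbon would move the number beyond the scatter remains open. Also open, from the compounds shown here alone, is whether changes elsewhere on the shared core would do so.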